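A few compounds are considered here, and "the series" means these few. Any claim that something is new, unique, unknown or untested is made for them only; others in the source may bear on it.

Measured so far in a functional assay on cardiac atrium for agonist activity at histamine H2 receptor (Cavia porcellus); on this read-out higher numbers stand for an effect only at larger amounts of compound and lower numbers for an effect already at smaller amounts:
- compound 1, `N=C(NCCCc1c[nH]cn1)NC(=O)CC(c1ccccc1)c1nccs1`: 38 nM
- compound 2, `N=C(NCCCc1c[nH]cn1)NC(=O)CC(c1ccc(F)c(F)c1)c1nccs1`: 50.1 nM

Compound 2 gives the higher of the two numbers in this assay, but its separation from compound 1 is only a 1.3-fold higher number from compound 1 to compound 2 (0.12 log units; within the scatter), which is inside the usual scatter; the two compounds are therefore to be read as equivalent on this read-out.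

Compound 3, `N=C(NCCCc1c[nH]cn1)NC(=O)CC(c1ccc(F)c(F)c1)c1ncc[nH]1`, differs from compound 2 by 1H-imidazol-2-yl in place of 1,3-thiazol-2-yl on a saturated chain carbon bound to an aromatic carbon and a saturated chain carbon. Among the compounds with values here, the only measured step, from compound 1 to compound 2, concerns the aryl group and not the five-membered heteroaryl, so it does not bear on this exchange; no measured pair shows what swapping the thiazolyl for an imidazolyl does here. The step is accordingly unanchored by the data, and the expectation rests only on the fact that the shared core of compound 2 is untouched and the two compounds keep the same ring size and heteroatom count at that position.

Working estimate: compound 3 is expected at about 100 nM in this assay, with a plausible range of 20 nM to 500 nM, that is an expected step of a 2.0-fold higher number from compound 2 to compound 3 (0.30 log units; within the scatter) from compound 2, with the wide range reflecting the absence of any precedent for the change.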

Compound 3, half-maximal effective concentration: 97.7 nM
Estimate against measurement, compound 3: 1.0-fold (0.01 log units) above; the range from low to high includes it.
By their numbers in this assay, from the lowest: compounds 1, 2 and 3 (each within the scatter of the next, the first and the last beyond it).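

In this assay, the exchange of 1,3-thiazol-2-yl for 1H-imidazol-2-yl on a saturated chain carbon bound to an aromatic carbon and a saturated chain carbon gives a 2.0-fold higher number from compound 2 to compound 3 (0.29 log units; within the scatter), so the read-out does not separate the two heteroaryl groups. Within the data shown here, this is the first reading on the heteroaryl group, as the earlier step concerned only the aryl group; here the sulfur-containing ring, with 0 hydrogen-bond donors and 2 hydrogen-bond acceptors, gives way to a ring with 1 hydrogen-bond donor and 1 hydrogen-bond acceptor without a step beyond the scatter. No independent data bear on why the exchange behaves this way.

The compounds shown place 1H-imidazol-2-yl only alongside 3,4-difluorophenyl, so it remains open whether the same exchange reads alike alongside unsubstituted phenyl. Also open, as far as these compounds go, is how this read-out responds when a six-membered ring such as pyridin-2-yl, an amine or a carboxylic acid stands at the same place, which would show how far the tolerance seen with these two five-membered rings extends.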